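Taking trifluoromethyl off compound 3: expected loss

The compounds below may be only part of what the source reports. "The series", "measured", "known", "first", "only" and "open" are said of these compounds alone.

In a functional assay on aorta (Rattus norvegicus, strain Wistar), in the presence of a further agent that is not named here (a higher number here means a weaker inhibitor, a lower number a stronger inhibitor), three compounds on a shared core have numbers. Compound 1 (`CC(=O)c1ccc2c(c1)N(C1=CCCC1=O)CC(C)(C)S2`) gives 56.2 nM, compound 2 (`CCc1ccc2c(c1)N(C1=CCCC1=O)CC(C)(C)S2`) gives 6460 nM and compound 3 (`CC1(C)CN(C2=CCCC2=O)c2cc(C(F)(F)F)ccc2S1`) gives 8.32 nM. Compound 3 is the strongest inhibitor of the three, and both gaps lie beyond the scatter: a 6.8-fold lower number from compound 1 to compound 3 (0.83 log units; beyond the scatter) and a 780-fold lower number from compound 2 to compound 3 (2.89 log units; beyond the scatter).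

Compound 4 (`CC1(C)CN(C2=CCCC2=O)c2ccccc2S1`) is still unmeasured. It differs from compound 3 as follows: hydrogen in place of trifluoromethyl on an aromatic carbon.

For the measured compounds named here, no measured step puts hydrogen at this carbon, so the evidence is indirect. Changes of group at this carbon can be large, as with ethyl in place of acetyl, a 110-fold higher number from compound 1 to compound 2 (2.06 log units; beyond the scatter), and trifluoromethyl in place of ethyl, a 780-fold lower number from compound 2 to compound 3 (2.89 log units; beyond the scatter). The exchange between the two groups with low numbers is only modest, at a 6.8-fold lower number from compound 1 to compound 3 (0.83 log units; beyond the scatter). Compound 2 shows that losing the low number needs no more than an ethyl group at this carbon, and hydrogen resembles neither trifluoromethyl nor acetyl by name. A large step towards a higher number is therefore expected, though with wide uncertainty. The expected step is a 96-fold higher number from compound 3 to compound 4 (1.98 log units; beyond the scatter). The estimate for compound 4 is 800 nM, with an expected range from 150 nM to 4500 nM.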

Compound 4, half-maximal inhibitory concentration: 20900 nM
Compound 4: the middle estimate sits 26-fold (1.42 log units) below what was measured; measured number above the stated range.
By their numbers in this assay, from the lowest: compound 3; then compound 1; then compound 2; then compound 4.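

Working notes on this position: in this assay the hydrogen compound has the highest number of the four, and a 2500-fold higher number from compound 3 to compound 4 (3.40 log units; beyond the scatter) is the largest step seen at this carbon, while a 370-fold higher number from compound 1 to compound 4 (2.57 log units; beyond the scatter) shows that acetyl also stands far from hydrogen. Ethyl stands much closer, with a 3.2-fold higher number from compound 2 to compound 4 (0.51 log units; beyond the scatter) still beyond the scatter but modest, so within this set the low numbers belong to trifluoromethyl and acetyl, whereas ethyl gives only a small move away from hydrogen. No measurement available here explains this split between the groups, so the result stands as a description of the numbers only.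

The compounds shown leave open whether a nitrile or a chlorine atom at this carbon would reach the low numbers of trifluoromethyl and acetyl, and whether an amine, a carboxylic acid or a longer chain would stay with ethyl and hydrogen at the high end. Also open, as far as these compounds go, is whether this order of the four groups would hold if another part of the shared core were changed.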